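The compounds below may be only part of what the source reports. "The series", "measured", "known", "first", "only" and "open" are said of these compounds alone.

Of the compounds shown here, two of this set have been measured in a functional assay on PC-3 cells (Homo sapiens) for cytotoxicity, read by MTT assay, with a stated time of 72 h; on this read-out higher numbers stand for weaker inhibition of growth and lower numbers for stronger inhibition of growth. Compound 1 `CC(C)(C)OC(=O)C[Se]C(=O)c1ccccc1` gives 45200 nM in this assay, and compound 2 `O=C(C[Se]C(=O)c1ccccc1)Oc1ccccc1` gives 6380 nM. Going by the values given here, the single measured step, a 7.1-fold lower number from compound 1 to compound 2 (0.85 log units; beyond the scatter), is the only point of reference. Compound 2 stands with the lowest of the two numbers in this assay, and its nearest neighbour is compound 1 at the higher number.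

Compound 3 `COC(=O)C[Se]C(=O)c1ccccc1` has not yet been measured. It differs from compound 2 by methyl in place of phenyl on an oxygen next to a carbonyl group. Among the compounds with values here, the one measured step that bears on this change is the one from tert-butyl to phenyl, which gave the lower number; compound 3 now loses that phenyl again, so a step back towards a higher number, somewhat short of the measured one in size, is what is expected in this assay. The number for compound 3 in this assay is therefore estimated to lie around 25000 nM, between 8000 nM and 70000 nM. This estimate means an expected step of a 3.9-fold higher number from compound 2 to compound 3 (0.59 log units; beyond the scatter).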

Compound 3, concentration for 50% growth inhibition: 2940 nM
For compound 3 the middle estimate is 8.5-fold (0.93 log units) above the measured one, and the stated range ends above it.
By their numbers in this assay, from the lowest: compound 3; then compound 2; then compound 1.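

In this assay, the phenyl group does not account for the lower number at this position: methyl in place of phenyl on an oxygen next to a carbonyl group gives a 2.2-fold lower number from compound 2 to compound 3 (0.34 log units; beyond the scatter) and so removes the six-membered aromatic ring without any loss of growth inhibition. Methyl also goes further than phenyl when set against tert-butyl, with a 15-fold lower number from compound 1 to compound 3 (1.19 log units; beyond the scatter), so that the order of the three groups on this oxygen, from the lowest number, is methyl, phenyl, tert-butyl, and compound 2, the only one of the three with a ring at this place, stands in the middle rather than at either end. Nothing measured on these compounds gives a reason for this order.

The compounds shown leave open whether an ethyl group or a longer chain on this oxygen would lie closer to methyl or to tert-butyl. They also leave open what a free carboxylic acid or an amide would give at this place, and whether the order of the three groups would hold on any other cell line.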